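Bromine on the Hydrazone Ring: Expected Cytotoxicity

This account rests on a few compounds, and the source may have more. Where it says the series, first, only, none or still open, it means among the compounds named here.

Measured compounds:
Compound 1, `C/C(=N\NC(=O)COc1cccc2ccccc12)c1ccccc1` — 20 ug/mL
Compound 2, `C/C(=N\NC(=O)COc1cccc2ccccc12)c1ccccc1Br` — 16.2 ug/mL
Compound 3, `O=C(COc1cccc2ccccc12)N/N=C/c1ccccc1` — 64.5 ug/mL

All three were tested in an ADME assay on HEL cells (Homo sapiens) for cytotoxicity; a higher number here means that more compound is tolerated, a lower number that less compound is tolerated. Compound 1 and compound 2 share a core and differ by one change, (bromo in place of hydrogen on an aromatic carbon). That change made a step of a 1.2-fold lower number from compound 1 to compound 2 (0.09 log units; within the scatter), so the two numbers cannot be told apart. Compound 3 has a different core; how the cores of compound 3 and compound 1 differ is not broken down here. In this assay compound 3 gives 64.5 ug/mL, the highest of the three numbers, and its distance from compound 1 and from compound 2 is beyond the scatter.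

Compound 4, `O=C(COc1cccc2ccccc12)N/N=C/c1cccc(Br)c1`, has not been measured. It comes from compound 3 by bromo in place of hydrogen on an aromatic carbon. This is the same kind of change as the one from compound 1 to compound 2, made twice among these compounds, but not the same: in compound 2 the bromo sits ortho to a large group, in compound 4 it sits meta to a large group. Because the step from compound 1 to compound 2 was a 1.2-fold lower number from compound 1 to compound 2 (0.09 log units; within the scatter), the step from compound 3 to compound 4 in this assay is expected to be small too, about a 1.2-fold lower number from compound 3 to compound 4 (0.07 log units; within the scatter). Compound 4 is therefore estimated to give around 55 ug/mL in this assay, with a likely range from 30 ug/mL to 100 ug/mL.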

Compound 4, half-maximal cytotoxic concentration in the HEL assay: 48.6 ug/mL
For compound 4 the middle estimate is 1.1-fold (0.05 log units) above the measured one, and the stated range covers the measured number.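

In the HEL assay the bromo change gives a small step on the core of compound 3, a 1.3-fold lower number from compound 3 to compound 4 (0.12 log units; within the scatter), and this matches the step seen on the core of compound 1: the same change on two cores in the HEL assay, a 1.2-fold lower number (0.09 log units; within the scatter) from compound 1 to compound 2 and a 1.3-fold lower number (0.12 log units; within the scatter) from compound 3 to compound 4, 1.1-fold (0.03 log units) apart, within the scatter of two such steps. This shows that, for these two pairs, replacing a hydrogen on the aromatic ring with bromo carried over from one core to the other without a step that can be told from the scatter, although it does not show that this holds on other cores, and the bromo does not sit in the same ring place in compound 2 and compound 4. The same change on the core of compound 3 did leave a clear mark in a physicochemical assay for lipophilicity, measured as octanol-water partition (on this read-out higher numbers stand for higher lipophilicity and lower numbers for lower lipophilicity), so a steady cytotoxicity number does not mean that the compounds are alike in every measured property: the measured partition coefficient of compound 3, 4.02, and of compound 4, 4.81, a number 0.79 log units higher (beyond the scatter). In the physicochemical assay compound 3 gives 4.02 and compound 4 gives 4.81 on this read-out.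

The compounds shown leave open whether an amine or a carboxylic acid in place of the bromo would also leave the cytotoxicity number steady on these two cores. They also leave open whether a bromo at the same ring place on both cores would give steps as close as these.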